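A few compounds are considered here, and "the series" means these few. Any claim that something is new, unique, unknown or untested is made for them only; others in the source may bear on it.

Three compounds have so far been measured in an ADME assay on the whole organism (strain C57BL/6J) for metabolic stability, with Mus musculus as the target; a lower number here means that the compound disappears faster, a higher number that the compound lasts longer:

Compound 1, `O=C(O)c1cccc(C2CC2c2ccc(OCc3c(-c4c(Cl)cccc4Cl)noc3C3CC3)cc2Cl)c1`, gives 1 h.
Compound 2, `O=C(O)c1ccc(C2CC2c2ccc(OCc3c(-c4c(Cl)cccc4Cl)noc3C3CC3)cc2Cl)cc1`, gives 0.5 h.
Compound 3, `O=C(O)c1cccc([C@H]2C[C@](O)(c3ccc(OCc4c(-c5c(Cl)cccc5Cl)noc4C4CC4)cc3Cl)C2)c1`, gives 0.6 h.

Compound 1 and compound 2 share one core and differ in a single place: 4-carboxyphenyl in place of 3-carboxyphenyl on a saturated ring carbon. That change produced a 2.0-fold lower number from compound 1 to compound 2 (0.30 log units; within the scatter), so the two numbers cannot be told apart with confidence. Compound 3 is built on a different core; the difference between the two cores is not broken down here. Its number and the numbers of compound 1 and compound 2 all lie within the usual scatter of one another, so no ordering among the three can be claimed.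

Compound 4, `O=C(O)c1ccc([C@H]2C[C@](O)(c3ccc(OCc4c(-c5c(Cl)cccc5Cl)noc4C4CC4)cc3Cl)C2)cc1`, has not yet been measured in this assay. It differs from compound 3 in one place: 4-carboxyphenyl in place of 3-carboxyphenyl on a saturated ring carbon. Going by the values given here, this is the same kind of change as the one from compound 1 to compound 2, but its surroundings differ. In compound 1 the carboxyphenyl group sits on a saturated ring carbon of a three-membered non-aromatic ring of carbon only, next to the ring atom that bears a large group. In compound 3 it sits on a saturated ring carbon of a four-membered non-aromatic ring of carbon only, two ring bonds from the ring atom that bears a hydroxy group and two ring bonds from the ring atom that bears a large group.

Among the compounds with values here, with only one earlier example of this change, the step from compound 3 to compound 4 is expected to be about a 1.5-fold lower number from compound 3 to compound 4 (0.18 log units; within the scatter), resting on the earlier result a 2.0-fold lower number from compound 1 to compound 2 (0.30 log units; within the scatter) and on the small numbers throughout. Compound 4 is therefore estimated at 0.4 h, most likely between 0.2 h and 0.8 h.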

Compound 4, half-life: 1.1 h
The estimate for compound 4 lay 2.8-fold (0.44 log units) below the measured number; measured number outside the range, above it.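

In this assay, putting 4-carboxyphenyl in place of 3-carboxyphenyl on the core of compound 3 gave a 1.8-fold higher number from compound 3 to compound 4 (0.26 log units; within the scatter) and so, taken alone, this step cannot be told apart from the ordinary spread of repeated measurements. Its real interest appears when it is set beside the earlier example, since the same change does not behave as one fixed step on both cores: the same change on two cores in this assay, a 2.0-fold lower number (0.30 log units; within the scatter) from compound 1 to compound 2 and a 1.8-fold higher number (0.26 log units; within the scatter) from compound 3 to compound 4, 3.7-fold (0.56 log units) apart, beyond the scatter of two such steps. Going by these compounds alone, this shows that the result of this change on one core was a poor guide to its result on the other, but it does not show why, and with only two cores it gives no rule for any further core, nor does it establish on either core alone which placement of the carboxyphenyl group lasts longer.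

The two cores differ in more than one place, so these compounds cannot say whether the size of the saturated ring, the hydroxy group or the way the ring is joined lies behind the gap between the steps. Also open, as far as these compounds go, is whether the same gap would appear if an amide or a nitrile stood where the carboxylic acid stands, or a methoxy group where the hydroxy group stands.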